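The source may hold more compounds than are shown below. What is called first, only, known or untested is meant among the compounds shown, and "the series" means these compounds.

Values so far in a physicochemical assay for solubility; a lower number here means a less soluble compound, a higher number a more soluble compound
- compound 1 `O=C(Nc1ccccc1Cl)c1cc(Cl)ccc1O` gives 5 ug/mL
- compound 2 `O=C(Nc1ccc(F)cc1Cl)c1cc(Cl)ccc1O` gives 1.2 ug/mL
- compound 3 `O=C(Nc1ccc(F)cc1F)c1cc(Cl)ccc1O` gives 1 ug/mL

Compound 2 (1.2 ug/mL) stands level with compound 3 within the scatter (a 1.2-fold lower number from compound 2 to compound 3 (0.08 log units; within the scatter)), and compound 1 lies clearly higher (a 4.2-fold lower number from compound 1 to compound 2 (0.62 log units; beyond the scatter)). The next compound to read is compound 4 `CC(=O)Nc1ccc(NC(=O)c2cc(Cl)ccc2O)c(Cl)c1`, which carries acetamido in place of fluoro on an aromatic carbon, meta to a chloro group and para to a large group (acetamido in place of fluoro on an aromatic carbon).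

For the measured compounds named here, two measured steps bear on this. The one at this same place replaced hydrogen with fluoro (a 4.2-fold lower number from compound 1 to compound 2 (0.62 log units; beyond the scatter)) and is modest but beyond the scatter. The other, fluoro in place of chloro (a 1.2-fold lower number from compound 2 to compound 3 (0.08 log units; within the scatter)), sits elsewhere and gives little guidance. Going by the values given here, no measured compound carries acetamido, so the direction rests only on fluoro leaving, as in the step to compound 2 from compound 1 (5 ug/mL), and remains uncertain.

A modest upward move is expected, estimated as a 2.5-fold higher number from compound 2 to compound 4 (0.40 log units; beyond the scatter) in this reading. The expected value for compound 4 is 3 ug/mL (estimated range 0.8 ug/mL to 12 ug/mL).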

Compound 4, solubility: 5.1 ug/mL
The estimate for compound 4 lay 1.7-fold (0.23 log units) below the measured number, within the range that was stated.
By their numbers in this assay, from the lowest: compounds 3 and 2 (each within the scatter of the next); then compounds 1 and 4 (each within the scatter of the next).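

In this assay, the place para to a large group can now be seen to move the number upward as well as downward: acetamido in place of fluoro gives a 4.3-fold higher number from compound 2 to compound 4 (0.63 log units; beyond the scatter) and so runs opposite to the earlier step with fluoro in place of hydrogen. Acetamido in place of hydrogen gives a 1.0-fold higher number from compound 1 to compound 4 (0.01 log units; within the scatter) and so leaves compound 4 level with compound 1 within the scatter, which means that at this place only fluoro separates from hydrogen among the groups shown. Nothing on hand accounts for either step.

Still open, going by these compounds, is whether this level is particular to acetamido or also holds for other groups at this place, such as an amine, a carboxylic acid or a longer chain. Also open, on these data alone, is whether the same change carries over to the core of compound 3, which has fluoro in place of the chloro group.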